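Cyclopropyl in Place of Methoxyphenyl: An Expected Value

The compounds below may be only part of what the source reports. "The series", "measured", "known", "first", "only" and "open" are said of these compounds alone.

The measured compounds, all tested in a functional assay on HeLa cells (Homo sapiens) for antiproliferative activity, read by MTT assay, with a stated time of 72 h; on this read-out higher numbers stand for weaker inhibition and lower numbers for stronger inhibition:
Compound 1 `Cc1ccc(S(=O)(=O)NCc2cn(C[C@H](O)[C@H]3OC(=O)C(OCc4ccccc4)=C3OCc3ccccc3)nn2)cc1` gives 14400 nM.
Compound 2 `O=C1O[C@H]([C@@H](O)Cn2cc(-c3cc(F)cc(F)c3)nn2)C(OCc2ccccc2)=C1OCc1ccccc1` gives 40800 nM.
Compound 3 `COc1ccc(-c2cn(C[C@H](O)[C@H]3OC(=O)C(OCc4ccccc4)=C3OCc3ccccc3)nn2)cc1` gives 16400 nM.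

All three share one core and differ only in the group carried on an aromatic carbon of the five-membered ring with three nitrogens. Compound 3 stands second highest of the three numbers: its step to compound 1, a 1.1-fold higher number from compound 1 to compound 3 (0.06 log units; within the scatter), is within the scatter, so the two cannot be ordered, while the step of a 2.5-fold lower number from compound 2 to compound 3 (0.40 log units; beyond the scatter) is a modest one beyond the scatter.

Compound 4 `O=C1O[C@H]([C@@H](O)Cn2cc(C3CC3)nn2)C(OCc2ccccc2)=C1OCc1ccccc1` carries the change (cyclopropyl in place of 4-methoxyphenyl on an aromatic carbon). Within the data shown here, no measured step swaps an aromatic group for a small non-aromatic ring, so the two steps that bear on it only loosely are a 2.5-fold lower number from compound 2 to compound 3 (0.40 log units; beyond the scatter) and a 1.1-fold higher number from compound 1 to compound 3 (0.06 log units; within the scatter); they show that exchanging groups at this position moves this assay by modest amounts at most. A step of about that size in either direction, or none beyond the scatter, is therefore expected for compound 4, written as a 1.3-fold higher number from compound 3 to compound 4 (0.13 log units; within the scatter). The estimate for compound 4 is 22000 nM, with a range from 8000 nM to 60000 nM.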

Compound 4, half-maximal inhibitory concentration: 26500 nM
For compound 4 the middle estimate is 1.2-fold (0.08 log units) below the measured one; measured number inside the range.
By their numbers in this assay, from the lowest: compounds 1, 3, 4 and 2 (each within the scatter of the next, the first and the last beyond it).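

Compound 4 is the first of these compounds whose group on this aromatic carbon holds no six-membered aromatic ring: cyclopropyl, with 3 heavy atoms, stands where 4-methoxyphenyl had 8. In this assay this change gives a 1.6-fold higher number from compound 3 to compound 4 (0.21 log units; within the scatter) and the comparisons with the other two groups give a 1.5-fold lower number from compound 2 to compound 4 (0.19 log units; within the scatter) and a 1.8-fold higher number from compound 1 to compound 4 (0.26 log units; within the scatter) so none of the three steps leaves the scatter. Among these four compounds, then, a six-membered aromatic ring in this group is not needed to stay within the scatter of the others, and this much smaller ring cannot be ordered against any of the three larger groups, even though compound 1 and compound 2 remain apart from each other.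

Nothing shown here gives a reason why the numbers stay so close across such different groups. As far as these compounds go, it also remains open whether an amine or a carboxylic acid on this carbon, or a longer alkyl chain in place of cyclopropyl, would carry the number beyond the scatter in either direction.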